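The source may report more compounds than this note shows. Statements on the series, on what has been measured and on what is new or still open speak of the compounds shown alone.

Of the compounds shown here, three have so far been measured in a functional assay on HT-29 cells (Homo sapiens) for inhibition, read by sulforhodamine B assay, with a stated time of 48 h; a higher number here means a weaker inhibitor of growth, a lower number a stronger inhibitor of growth. Compound 1 `O=CN1CCN(c2ccc(Cl)cc2)C1=S` gives 17200 nM. Compound 2 `N#C/C(=C\N1CCN(C(=O)c2ccco2)C1=S)C(N)=O` gives 24100 nM, and compound 3 `COc1cc(C(=O)N2CCN(C=O)C2=S)cc(OC)c1OC` gives 26700 nM. Among these three numbers compound 2 stands second highest, with compound 3 as its nearest neighbour and compound 1 as its furthest, yet all three values lie within the scatter of one another, so none of them can be called the stronger or the weaker inhibitor. Compound 4 `N#C/C(=C\N1CCN(C(=O)c2ccco2)C1=S)C(=O)Nc1ccc(Cl)cc1` differs from compound 2 in one place: 4-chlorophenyl in place of hydrogen on an amide-type nitrogen. Within the data shown here, no measured pair shows this change, so its size is not known from the data. The step from compound 2 to compound 4 is expected to be modest, roughly a 1.6-fold lower number from compound 2 to compound 4 (0.21 log units; within the scatter), toward a slightly lower number. Compound 4 is therefore estimated at 15000 nM, within a range from 5000 nM to 45000 nM.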

Compound 4, concentration for 50% growth inhibition: 21400 nM
Beside the measured number, compound 4's estimate is 1.4-fold (0.15 log units) below it, within the range that was stated.
By their numbers in this assay, from the lowest: compounds 1, 4, 2 and 3 (each within the scatter of the next).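

Among these compounds, this is the first pair of measured compounds that differ in one place. In this assay, placing 4-chlorophenyl on the amide-type nitrogen gives a 1.1-fold lower number from compound 2 to compound 4 (0.05 log units; within the scatter), so adding this whole ring at this position produces no change that can be read. No measurement shown here offers an explanation for this result.

Still open, on these data alone, is whether another group on this nitrogen, such as a short alkyl chain or a phenyl ring carrying a carboxylic acid, would move the number beyond the scatter.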